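One Methyl Added to a Compound at the Limit

The compounds below may be only part of what the source reports. "The series", "measured", "known", "first", "only" and "open" are said of these compounds alone.

In a physicochemical assay for lipophilicity, read by HPLC, measured as octanol-water partition, with a stated time of 24 h (a higher number here means a more lipophilic compound, a lower number a more polar compound), compound 1 `COc1ccc(Nc2nc(NC3CCCC3)c3ccccc3n2)cc1` gives > 5, which is a limit of the assay and not a number. Its close relative, compound 2 `COc1ccc(Nc2nc(NC3CC3)c3ccccc3n2)cc1`, offers no help, as its entry reads "not determined" (no result reported). Compound 3 `COc1ccc(N(C)c2nc(NC3CCCC3)c3ccccc3n2)cc1` differs from compound 1 in one place: methyl in place of hydrogen on a nitrogen on an aromatic ring, a methyl in place of hydrogen on a nitrogen on an aromatic ring. Within the data shown here, no measured pair shows the size of such a change, but a small rise is expected, an estimated step that the limit leaves unreadable from compound 1 to compound 3. The expected value for compound 3 is 5.5, within an estimated range from 5 to 6.2.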

Compound 3, partition coefficient: > 5
Compound 3 ended at the assay's limit (the forecaster's own chance of this, stated with the estimate: 75%); the middle value does not contradict the limit.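

Among these compounds, compound 1 and compound 3 both stand at a limit and not at a number, so no step between them can be read: the limit of > 5 in this assay, at which 2 of the 3 values shown sit.

In this assay the compounds shown leave open how large a change the methyl in place of hydrogen on a nitrogen on an aromatic ring makes.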